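Cyclohexyl in place of phenyl on the amide nitrogen

A few compounds are considered here, and "the series" means these few. Any claim that something is new, unique, unknown or untested is made for them only; others in the source may bear on it.

Compound 3 `C=CC1=C(C(=O)Nc2ccccc2)C(c2ccc(F)cc2)OC1` stands only at a limit in a functional assay on SW480 cells (Homo sapiens) for cytotoxicity, read by MTT assay, with a stated time of 24 h; a higher number here means a weaker inhibitor, a lower number a stronger inhibitor: compound 3 gives > 100000 nM, which is a limit of the assay and not a number. Compound 2 `C=CC1=C(C(=O)NCc2ccccc2F)C(c2ccc(F)cc2)OC1` likewise gives > 100000 nM, a limit. Compound 1 `C=CC1=C(C(=O)NC2CCCCC2)C(c2ccc(OC)cc2)OC1`, which already carries a cyclohexyl on its amide nitrogen, gives > 100000 nM, again a limit. Among the compounds with values here, the one measured step, a step that the two limits leave unreadable from compound 2 to compound 3, cannot be read because the limit of > 100000 nM in this assay, at which 3 of the 3 values shown sit, leaves both ends unresolved. Compound 4 `C=CC1=C(C(=O)NC2CCCCC2)C(c2ccc(F)cc2)OC1` differs from compound 3 by cyclohexyl in place of phenyl on an amide-type nitrogen. Within the data shown here, no measured step resolves such a change, and every value so far sits at the limit, so no step beyond the scatter is expected in either direction; the expected step is a step that the limit leaves unreadable from compound 3 to compound 4. The estimate for compound 4 is 150000 nM, between 100000 nM and 300000 nM, most likely reported again only as a limit.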

Compound 4, half-maximal inhibitory concentration: > 100000 nM
Compound 4: a limit, no number (the forecaster's own chance of this, stated with the estimate: 90%); the middle value does not contradict the limit.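

The steps to compound 4 from compound 1, compound 2 and compound 3 cannot be read, because each compound stands only at a limit, not a number: the limit of > 100000 nM in this assay, at which 4 of the 4 values shown sit.

The compounds shown leave open whether any group on the amide nitrogen of the shared core gives a measurable value.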